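A few compounds are considered here, and "the series" means these few. Any claim that something is new, unique, unknown or untested is made for them only; others in the source may bear on it.

Working notes on the series, followed in a functional assay on MCF7 cells (Homo sapiens) for antiproliferative activity, read by MTT assay, with a stated time of 24 h; a lower number here means a stronger inhibitor, a higher number a weaker inhibitor. Compound 1 `FC(F)(F)c1ccc(C2CC(c3ccccc3)=NN2c2ccc(-c3ccccc3)nn2)cc1` gives 100000 nM in this assay. Compound 2 `COc1ccc(C2CC(c3ccccc3)=NN2c2ccc(-c3ccccc3)nn2)cc1` gives 100000 nM in this assay. For the measured compounds named here, both sit at the same high value, and the one measured step, no change at the digits printed from compound 1 to compound 2 (within the scatter), shows that putting methoxy in place of trifluoromethyl on an aromatic carbon leaves the number where it was. Going by the values given here, compound 1 therefore stands level with compound 2, and on the numbers so far neither can be called the stronger or the weaker inhibitor.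

Compound 3 `FC(F)(F)c1ccc(C2CC(c3ccc(Cl)cc3)=NN2c2ccc(-c3ccccc3)nn2)cc1` has not yet been measured in this assay. It differs from compound 1 by chloro in place of hydrogen on an aromatic carbon, placed on an aromatic carbon of a six-membered aromatic ring of carbon only, para to a large group; read one bond further out, a phenyl becomes a 4-chlorophenyl. Among the compounds with values here, no measured step touches this ring of the shared core; the only step available, no change at the digits printed from compound 1 to compound 2 (within the scatter), concerns a different ring and was flat. Adding one chlorine to the shared core is not expected to move the number beyond the scatter, so a step of no change at the digits printed from compound 1 to compound 3 (within the scatter) is expected. Compound 3 is therefore expected to give about 100000 nM in this assay, within 30000 nM to 100000 nM.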

Compound 3, half-maximal inhibitory concentration: 1670 nM
Compound 3: middle estimate off by 60-fold (1.78 log units), on the high side, outside the stated range (below it).
By their numbers in this assay, from the lowest: compound 3; then compounds 1 and 2 (each within the scatter of the next).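

Chloro in place of hydrogen on an aromatic carbon of a six-membered aromatic ring of carbon only, para to a large group, gives a 60-fold lower number from compound 1 to compound 3 (1.78 log units; beyond the scatter) in this assay, so the series can leave the high value it held in compounds 1 and 2. For the compounds shown here, the response at this position contrasts with the only other step, no change at the digits printed from compound 1 to compound 2 (within the scatter), which changes a different ring and stays within the scatter; on these two steps, the phenyl that becomes 4-chlorophenyl responds while the trifluoromethyl-to-methoxy change does not, and a single added chlorine is enough to produce the large step. Nothing available here bears on the reason for this response at the position.

The compounds shown leave open whether the lower number is particular to chloro or would also follow from another group at the same place, such as a methyl, an amine or a carboxylic acid. They also leave open whether 4-chlorophenyl gives a step of similar size when methoxy stands in place of trifluoromethyl, as in the core of compound 2.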